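A few compounds are considered here, and "the series" means these few. Any claim that something is new, unique, unknown or untested is made for them only; others in the source may bear on it.

Compound 1 `S=C(Nc1ccccc1)N1N=C(c2ccccc2)CC1c1ccc2c(c1)OCCO2` carries an unsubstituted phenyl on the carbon with a double bond to nitrogen of the shared core, and in a functional assay on A-375 cells (Homo sapiens) for antiproliferative activity, read by MTT assay, with a stated time of 48 h (on this read-out higher numbers stand for weaker inhibition of growth and lower numbers for stronger inhibition of growth), compound 1 gives 1850 nM. Compound 2 `FC(F)(F)c1ccc(C2=NN(C(=S)Nc3ccccc3)C(c3ccc4c(c3)OCCO4)C2)cc1` gives 43500 nM, a 24-fold higher number from compound 1 to compound 2 (1.37 log units; beyond the scatter). Compound 3 `S=C(Nc1ccccc1)N1N=C(c2cccc(Cl)c2)CC1c1ccc2c(c1)OCCO2` sits at the limit of > 200000 nM in this assay, at which 1 of the 3 values shown sits; its value > 200000 nM is a limit of the assay and not a number. From the other two it stands at an at least 100-fold higher number from compound 1 to compound 3 (2.03 log units; beyond the scatter) and an at least 4.5-fold higher number from compound 2 to compound 3 (0.66 log units; beyond the scatter), the weakest of the three. Compound 4 `S=C(Nc1ccccc1)N1N=C(c2cccs2)CC1c1ccc2c(c1)OCCO2` differs by thiophen-2-yl in place of 3-chlorophenyl on a carbon with a double bond to nitrogen. Among the compounds with values here, no measured step touches thiophen-2-yl, but both steps into compound 3 show that the aryl on this carbon moves the number strongly, so compound 4 is expected to return toward a measurable value, a step of an at least 25-fold lower number from compound 3 to compound 4 (1.39 log units; beyond the scatter). Compound 4 is estimated at 8000 nM, within 800 nM to 150000 nM.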

Compound 4, concentration for 50% growth inhibition: 121000 nM
Compound 4: the middle estimate sits 15-fold (1.18 log units) below what was measured; the measured number falls inside the stated range.
By their numbers in this assay, from the lowest: compound 1; then compound 2; then compound 4. At a limit, above all of these: compound 3.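

In this assay, thiophen-2-yl on this carbon does not hold the activity seen with the plain phenyl: a 65-fold higher number from compound 1 to compound 4 (1.82 log units; beyond the scatter). It also gives weaker growth inhibition than 4-(trifluoromethyl)phenyl, with a 2.8-fold higher number from compound 2 to compound 4 (0.44 log units; beyond the scatter), so all three replacements shown lose ground to phenyl. Against compound 3 the comparison gives only an at least 1.6-fold lower number from compound 3 to compound 4 (0.21 log units; that floor lies within the scatter), since compound 3 stands at a limit and not a number: the limit of > 200000 nM in this assay, at which 1 of the 4 values shown sits.

The compounds shown leave open whether any group here can give a lower number than phenyl. They also leave open how an amine, a carboxylic acid or a longer chain on this carbon would behave.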